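The source may report more compounds than this note shows. Statements on the series, on what has been measured and on what is new or still open speak of the compounds shown alone.

Compound 2 `CNC(=O)[C@@]12C[C@@H]1[C@@H](n1cnc3c(NC)nc(C#Cc4cccnn4)nc31)[C@H](O)[C@@H]2O` stands lowest of the two numbers measured in an assay on CHO cells for displacement of a labelled ligand from adenosine receptor A1 (Homo sapiens), read by scintillation counting, with a stated time of 60 min, tested at 10 uM (a higher number here means more inhibition at the concentration tested (going by the name of the read-out), a lower number less inhibition), where compound 2 gives 11%. Its nearest neighbour is compound 1 `CNC(=O)[C@@]12C[C@@H]1[C@@H](n1cnc3c(NC)nc(C#Cc4ccc(-c5ccccc5)cc4)nc31)[C@H](O)[C@@H]2O`, which in this assay gives 18%, and the step of a number 7 percentage points lower from compound 1 to compound 2 (within the scatter) lies within the scatter, so the two compounds cannot be ordered. Compound 3 `CNC(=O)[C@@]12C[C@@H]1[C@@H](n1cnc3c(NC)nc(C#Cc4cnn(C)c4)nc31)[C@H](O)[C@@H]2O` has not yet been measured. It differs from compound 2 by 1-methyl-1H-pyrazol-4-yl in place of pyridazin-3-yl on a triple-bonded carbon. Going by the values given here, the only measured step that bears on this change is the one that also exchanged the aromatic ring on the triple-bonded carbon, and that step, a number 7 percentage points lower from compound 1 to compound 2 (within the scatter), stayed within the scatter. One exchange of the ring at that position therefore did not move the number beyond the scatter, and with nothing else to go on the expectation is that replacing pyridazin-3-yl with 1-methyl-1H-pyrazol-4-yl also yields no step beyond the scatter. The expected step is a number 1 percentage points higher from compound 2 to compound 3 (within the scatter). Compound 3 is thus estimated in this assay at 12%, with a range from 0% to 30%.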

Compound 3, a percentage reported as inhibition, at one concentration (the size of the read-out at that concentration, not a potency): 35%
Estimate against measurement, compound 3: 23 percentage points below; the whole stated range lies below it.
By their numbers in this assay, from the lowest: compounds 2 and 1 (each within the scatter of the next); then compound 3.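

In this assay, the group on the triple-bonded carbon proves able to move the number beyond the scatter: 1-methyl-1H-pyrazol-4-yl in place of pyridazin-3-yl gives a number 24 percentage points higher from compound 2 to compound 3 (beyond the scatter), even though the two groups match in heavy atoms, hetero atoms and hydrogen-bond acceptors and differ in that one is a five-membered and the other a six-membered aromatic ring. The same group also separates from 4-phenylphenyl, with a number 17 percentage points higher from compound 1 to compound 3 (beyond the scatter), so compound 3 stands apart from both other compounds, while compound 1 and compound 2 still cannot be ordered. Nothing available explains why this exchange shifts the number in this assay.

The compounds shown leave open whether the step belongs to the five-membered ring or to its methyl group, a question that the 1H-pyrazol-4-yl group without the methyl, or the same ring bearing an ethyl group or a longer chain, would address. They also leave open how far the number could rise with a polar substituent such as an amine or a carboxylic acid on that ring.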